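Dropping a terminal hydroxy from a long chain

The source may hold more compounds than are shown below. What is called first, only, known or untested is meant among the compounds shown, and "the series" means these compounds.

Of the compounds shown here, three on one shared core have been tested in an assay (Cricetulus griseus) for inhibition of aldehyde dehydrogenase, mitochondrial (Homo sapiens); on this read-out lower numbers stand for stronger inhibition and higher numbers for weaker inhibition. Compound 1 `O=C(O)COc1ccc(-c2coc3cc(OCC(=O)O)ccc3c2=O)cc1` gives only a limit in this assay, >> 9000 nM. Compound 2 `O=c1c(-c2ccc(O)cc2)coc2cc(OCCCCCCCCCCCCO)ccc12` gives 1700 nM in this assay. Compound 3 `CCCCCCC(Oc1ccc2c(=O)c(-c3ccc(O)cc3)coc2c1)C(=O)O` gives 2000 nM in this assay, a number within the scatter of that of compound 2, so the two are not distinguished here. Compound 4 `CCCCCCCCCCCCOc1ccc2c(=O)c(-c3ccc(O)cc3)coc2c1` differs from compound 2 in a single place: hydrogen in place of hydroxy on a saturated chain carbon, ten or more bonds along the chain from an oxygen on an aromatic ring. Among the measured compounds shown here, no measured pair shows this exact change. The expected step, a 1.4-fold lower number from compound 2 to compound 4 (0.15 log units; within the scatter), points toward slightly stronger inhibition, or none beyond the scatter. Compound 4 is therefore estimated at 1200 nM, with a range from 400 nM to 4000 nM.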

Compound 4, half-maximal inhibitory concentration: > 9000 nM
Compound 4 ended at the assay's limit (the forecaster's own chance of this, stated with the estimate: 10%); middle value at least 7.5-fold (0.87 log units) away from the limit.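

Losing the terminal hydroxy is not a neutral change, since in this assay it gives an at least 5.2-fold higher number from compound 2 to compound 4 (0.72 log units; beyond the scatter), which means weaker inhibition. Among the compounds shown here, the end of this long chain therefore matters, something the earlier compounds could not show because none of them pairs a chain with and without this hydroxy. Compound 4 gives only a limit, so the step has a floor and no exact size: the limit of > 9000 nM in this assay, at which 1 of the 4 values shown sits.

Still open, on these data alone, is whether an amine or a methoxy at the chain end would serve as the hydroxy does. As far as these compounds go, whether a shorter or longer chain carrying the hydroxy keeps this inhibition is also open.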